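This account rests on a few compounds, and the source may have more. Where it says the series, first, only, none or still open, it means among the compounds named here.

Compound 1 `Cc1cc(NC(=O)Nc2cccc(Cl)c2)c2ccccc2n1`, 800 nM; compound 2 `Cc1cc(NC(=O)Nc2ccc(O)cc2)c2ccccc2n1`, 100 nM.

In a physicochemical assay for solubility, at pH 7.4 (a lower number here means a less soluble compound, a higher number a more soluble compound), compound 2 gives the lowest of the two numbers, with compound 1 the nearest measured compound an 8.0-fold lower number from compound 1 to compound 2 (0.90 log units; beyond the scatter). Compound 3 `CCc1ccc(NC(=O)Nc2cc(C)nc3ccccc23)cc1` differs from compound 2 by ethyl in place of hydroxy on an aromatic carbon. Going by the values given here, the only measured step that bears on this is the one from compound 1 to compound 2, and it changed a group at the same position rather than this one; its size was an 8.0-fold lower number from compound 1 to compound 2 (0.90 log units; beyond the scatter). Given that, the number for compound 3 is expected to move back upward, by roughly a 4.0-fold higher number from compound 2 to compound 3 (0.60 log units; beyond the scatter). Compound 3 is estimated at 400 nM, in the range 100 nM to 1600 nM.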

Compound 3, solubility: 3300 nM
Beside the measured number, compound 3's estimate is 8.3-fold (0.92 log units) below it; measured number outside the range, above it.
By their numbers in this assay, from the lowest: compound 2; then compound 1; then compound 3.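

In this assay, ethyl in place of hydroxy on an aromatic carbon gives a 33-fold higher number from compound 2 to compound 3 (1.52 log units; beyond the scatter). Going by these compounds alone, this is the first step in which only the group para to a large group changes, so this one position can carry a large change on its own. Within the data shown here, the change also takes away the hydrogen-bond donor and acceptor counted for hydroxy, but the single step cannot separate that loss from the added carbon atoms, and no measurement here accounts for its size.

From the compounds shown here alone, whether a methoxy group, an amine or a longer chain at this position would lie nearer compound 2 or compound 3 remains open.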